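The source may hold more compounds than are shown below. What is called first, only, known or untested is meant among the compounds shown, and "the series" means these compounds.

Compound 2 `Cc1ccc(C2=CC(c3ccccc3)C3=C(CC(C)(C)CC3=O)N2)cc1` was tested in an assay on isolated protein for inhibition of glucose-6-phosphatase catalytic subunit 1 (Homo sapiens), read by inositol phosphate accumulation, with a stated time of 30 min, tested at 100 uM (on this read-out higher numbers stand for more inhibition at the one concentration tested (going by the name of the read-out) and lower numbers for less inhibition), and there compound 2 gave "not active" (no number reported), so no single number stands for it. It is not alone in that: compound 1 `CCOC(=O)C1(O)CC(c2ccc(Cl)cc2)C2=C(CC(C)(C)CC2=O)O1` also gave "not active" (no number reported) in this assay, and it is the only other entry without a number. Among the measured compounds shown here, the one compound with a figure is compound 3 `CC1(C)CC(=O)c2c(-c3ccc(Cl)cc3)cc(-c3ccccc3)nc2C1`, which in this assay gave 11.3%, a small effect at the single concentration tested.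

The compound that follows is compound 4 `CC1(C)CC(=O)C2=C(C1)NC(c1ccccc1)=CC2c1ccccc1`, which differs from compound 2 in a single place: hydrogen in place of methyl on an aromatic carbon. The group that leaves is a methyl on an aromatic carbon of a six-membered aromatic ring of carbon only, para to a large group, and a hydrogen takes its place, so that a 4-methylphenyl becomes a phenyl.

For the measured compounds named here, no measured pair differing in just this way is available, so the size of the step has to be guessed. Since compound 2 gave "not active" (no number reported) in this assay, and nothing among the three compounds points to a larger effect, the expectation is a step that stays within the usual scatter, in no particular direction. Compound 4 is therefore expected to give about 5% in this assay, with a likely range from 0% to 15%.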

Compound 4, a percentage reported as inhibition, at one concentration (the size of the read-out at that concentration, not a potency): "not active" (no number reported)
Nothing numeric was reported for compound 4, so the estimate cannot be set against anything.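

Compound 2 and compound 4 both gave no number in this assay, so no step can be read for the change from 4-methylphenyl to phenyl. Nothing measured here offers an explanation for this result. The compounds shown leave open whether this change has any effect on inhibition in this test.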